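Chain extension on a sulfonyl-bearing core of weak acyltransferase inhibitors

The compounds below may be only part of what the source reports. "The series", "measured", "known", "first", "only" and "open" are said of these compounds alone.

Compound 1, `CCCCCCCn1nc(-c2ccccc2)c(-c2ccccc2)cc1=O`, and compound 2, `CCCCCCCCCn1nc(-c2ccccc2)c(-c2ccccc2)cc1=O`, share one core and differ only in the length of the chain on the ring nitrogen. In an assay on microsomes from liver for inhibition of sterol O-acyltransferase 1 (Rattus norvegicus) (a higher number here means a weaker inhibitor, a lower number a stronger inhibitor), compound 1 gives 86000 nM, and compound 2 gives 85000 nM. The change between them is ethyl in place of hydrogen on a saturated chain carbon, seven bonds along the chain from an aromatic nitrogen, and it produced a 1.0-fold lower number from compound 1 to compound 2 (0.01 log units; within the scatter). Compound 3, `CCCCCCS(=O)(=O)c1cc(-c2ccccc2)c(-c2ccccc2)nn1`, carries a different core in which the chain hangs from a sulfonyl group; the difference between the core of compound 1 and the core of compound 3 is not broken down here. In this assay compound 3 gives 60000 nM, a number within the scatter of those of compound 1 and compound 2, so the three measured compounds cannot be told apart on this read-out.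

Compound 4, `CCCCCCCCS(=O)(=O)c1cc(-c2ccccc2)c(-c2ccccc2)nn1`, is not yet measured. It is related to compound 3 by ethyl in place of hydrogen on a saturated chain carbon, six bonds along the chain from a sulfonyl sulfur. Among the measured compounds shown here, this is the same kind of change as the one from compound 1 to compound 2, but the place is not the same: there the ethyl entered seven bonds along the chain from an aromatic nitrogen, here it enters six bonds along the chain from a sulfonyl sulfur. Since the earlier step of the same kind, a 1.0-fold lower number from compound 1 to compound 2 (0.01 log units; within the scatter), lay within the scatter, compound 4 is expected to show a step of about no change at the digits printed from compound 3 to compound 4 (within the scatter) from compound 3 in this assay. For the measured compounds named here, the estimate for compound 4 in this assay is therefore 60000 nM, with a likely range from 25000 nM to 150000 nM, resting only on the single earlier example and the value of compound 3, 60000 nM.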

Compound 4, half-maximal inhibitory concentration: 36000 nM
Compound 4: middle estimate off by 1.7-fold (0.22 log units), on the high side; the range from low to high includes it.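

Ethyl in place of hydrogen on the chain of compound 3 gives a 1.7-fold lower number from compound 3 to compound 4 (0.22 log units; within the scatter) in this assay. Set beside the step on the other core, the change reads the same on both within what repeated measurements can separate: the same change on two cores in this assay, a 1.0-fold lower number (0.01 log units; within the scatter) from compound 1 to compound 2 and a 1.7-fold lower number (0.22 log units; within the scatter) from compound 3 to compound 4, 1.6-fold (0.22 log units) apart, within the scatter of two such steps This shows that, on these two cores, the change carries over without a step or a gap between steps that can be told from the scatter; it does not show that the chain has no effect on either core, or that the two cores truly respond alike, as each core offers only one pair and a modest real difference could lie hidden within the scatter.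

The compounds shown leave open whether a longer chain than those of compound 2 and compound 4, or a chain ending in a carboxylic acid or an amine, would give a step beyond the scatter on either core. They also leave open what the core itself contributes, as the core of compound 1 and the core of compound 3 are compared here only through chains that differ as well.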